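The compounds below may be only part of what the source reports. "The series", "measured", "known", "first", "only" and "open" are said of these compounds alone.

Of the compounds shown here, three sharing one core have been tested in a functional assay on DU-145 cells (Homo sapiens) for cytotoxicity, read by MTT assay; a higher number here means a weaker inhibitor, a lower number a stronger inhibitor. Compound 1 `CC(C)=CC[C@@H](OC(=O)c1ccco1)C1=CC(=O)c2c(O)ccc(O)c2C1=O` gives > 100000 nM, which is a limit of the assay and not a number. For the measured compounds named here, compound 2 `CCCCC(CC(=O)O[C@H](CC=C(C)C)C1=CC(=O)c2c(O)ccc(O)c2C1=O)OC(C)=O` gives 67700 nM, and compound 3 `CC(C)=CC[C@@H](OC(=O)C1CCCCO1)C1=CC(=O)c2c(O)ccc(O)c2C1=O` gives 24700 nM, the lowest number so far. Compound 4 `CCC(C)(O)CC(=O)O[C@H](CC=C(C)C)C1=CC(=O)c2c(O)ccc(O)c2C1=O` carries 2-hydroxy-2-methylbutyl in place of oxan-2-yl on a carbonyl carbon. The closest guide is the modest step of a 2.7-fold lower number from compound 2 to compound 3 (0.44 log units; beyond the scatter), where oxan-2-yl replaced the 2-acetoxyhexyl chain. The step of an at least 4.0-fold lower number from compound 1 to compound 3 (0.60 log units; beyond the scatter) concerns a ring swap and bears less directly. Reversing the first step suggests a modest rise in the number, so the expected change is a 1.6-fold higher number from compound 3 to compound 4 (0.21 log units; within the scatter). For compound 4 the estimated value is 40000 nM, with an expected range of 14000 nM to 100000 nM.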

Compound 4, half-maximal inhibitory concentration: 16000 nM
The estimate for compound 4 lay 2.5-fold (0.40 log units) above the measured number; low and high end bracket the measured number.
By their numbers in this assay, from the lowest: compounds 4 and 3 (each within the scatter of the next); then compound 2. At a limit, above all of these: compound 1.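

Replacing the oxan-2-yl ring with the open 2-hydroxy-2-methylbutyl chain gives a 1.5-fold lower number from compound 3 to compound 4 (0.19 log units; within the scatter), so among these compounds a ring at this place is not required. Against the 1-acetoxypentyl chain, 1-hydroxy-1-methylpropyl gives a 4.2-fold lower number from compound 2 to compound 4 (0.63 log units; beyond the scatter), a modest gain. Furan-2-yl stands at a limit of the assay, so only a floor can be read: an at least 6.2-fold lower number from compound 1 to compound 4 (0.79 log units; beyond the scatter).

From the compounds shown here alone, what the hydroxyl contributes stays open. A plain 2-methylbutyl chain or an amine-bearing chain at this place lies outside the compounds shown.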